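This account rests on a few compounds, and the source may have more. Where it says the series, first, only, none or still open, it means among the compounds named here.

Compound 1, `O=c1ccc(-c2ccccc2)nn1CCCC/N=C(\S)Nc1cccc(F)c1`, gives in a functional assay on the whole organism (stomach) with Rattus norvegicus as the target (a higher number here means that more compound is needed for the effect, a lower number that less compound is needed), a limit of > 100 mg/kg. Compound 2, `C/N=C(/NC#N)NCCCCn1nc(-c2ccccc2)c(C)cc1=O`, gives a limit of > 100 mg/kg. Compound 3, `CC/N=C(\S)NCCCn1nc(-c2ccccc2)ccc1=O`, gives a limit of > 100 mg/kg.

Compound 3 thus stands where every measured compound stands, at the limit of > 100 mg/kg in this assay, at which 3 of the 3 values shown sit, so nothing is known of it beyond that limit. Compound 4, `N#CNC(=N)NCCCn1nc(-c2ccccc2)ccc1=O`, differs from compound 3 by a group of 5 heavy atoms (2 carbon, 3 nitrogen; no ring) in place of a group of 5 heavy atoms (3 carbon, 1 nitrogen, 1 sulfur; no ring), on an amine nitrogen. Going by the values given here, no step between measured compounds is available, and with all three at the same limit, no movement beyond the usual scatter can be foreseen in either direction. Compound 4 is therefore expected to give about 100 mg/kg, with a range from 40 mg/kg to 300 mg/kg. That estimate means an expected step of a number no higher from compound 3 to compound 4 (the limit leaves the size open). Most likely this assay again reports only a limit for compound 4.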

Compound 4, dose for half-maximal effect: > 100 mg/kg
Compound 4: a limit, no number; the forecaster's own chance of this, stated with the estimate: 80%; the middle value sits exactly at the limit.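

No step can be read from compound 3 to compound 4, as each gives only a limit in this assay: the limit of > 100 mg/kg in this assay, at which 4 of the 4 values shown sit.

The compounds shown leave open where any of them lies beyond that limit, and whether exchanging the group on the amine nitrogen changes the dose needed at all.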